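The compounds below may be only part of what the source reports. "The series", "measured", "known", "first", "only" and "open" are said of these compounds alone.

Measured in a functional assay on HeLa cells (Homo sapiens) for inhibition, read by sulforhodamine B assay; on this read-out higher numbers stand for weaker inhibition and lower numbers for stronger inhibition:
- Compound 1 `O=C1C(Nc2ccc(I)cc2)=CC(=O)c2c1nc1n2[C@H]2OC[C@@H](O)[C@H]2OC1`: 4010 nM
- Compound 2 `COc1ccc(NC2=CC(=O)c3c(nc4n3[C@H]3OC[C@@H](O)[C@H]3OC4)C2=O)cc1`: > 8000 nM (a limit)
- Compound 3 `O=C1C(NC2CC2)=CC(=O)c2c1nc1n2[C@H]2OC[C@@H](O)[C@H]2OC1`: > 16000 nM (a limit)

Compound 3 has no exact number, only a limit: > 16000 nM. the limit of > 16000 nM in this assay, at which 1 of the 3 values shown sits, marks where it sits. Compound 4 `CCCc1ccc(NC2=CC(=O)c3c(nc4n3[C@H]3OC[C@@H](O)[C@H]3OC4)C2=O)cc1` differs from it in one place: 4-propylphenyl in place of cyclopropyl on an amine nitrogen. In words, that is 4-propylphenyl in place of cyclopropyl on an amine nitrogen.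

The closest measured change runs the opposite way. With cyclopropyl in place of 4-iodophenyl, the measured step is an at least 3.9-fold higher number from compound 1 to compound 3 (0.60 log units; beyond the scatter). Reversing that kind of swap suggests a lower number in this assay, meaning stronger inhibition. The other steps add little: an at least 1.9-fold higher number from compound 1 to compound 2 (0.29 log units; that floor lies within the scatter) and a step that the two limits leave unreadable from compound 2 to compound 3. Compound 2 also gives only a limit, > 8000 nM, so a group of this kind does not guarantee a number close to that of compound 1. A modest gain is therefore expected, and the expected step is an at least 3.2-fold lower number from compound 3 to compound 4 (0.50 log units; beyond the scatter). For compound 4 the estimate is 5000 nM, with an expected range of 2000 nM to 12000 nM.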

Compound 4, half-maximal inhibitory concentration: 6030 nM
Compound 4: middle estimate off by 1.2-fold (0.08 log units), on the low side; measured number inside the range.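

In this assay, 4-propylphenyl on the amine nitrogen gives a measured number where cyclopropyl gave only a limit, with an at least 2.6-fold lower number from compound 3 to compound 4 (0.42 log units; beyond the scatter). So compound 3 is now separated from a second aryl compound as well as from compound 1, and the step is a floor, so the real gap may be larger. On the aromatic carbon, propyl in place of iodo gives a 1.5-fold higher number from compound 1 to compound 4 (0.18 log units; within the scatter), while propyl in place of methoxy gives an at least 1.3-fold lower number from compound 2 to compound 4 (0.12 log units; that floor lies within the scatter), so neither swap sets the two groups apart.

From the compounds shown here alone, compound 2 and compound 3 both give limits and the step between them cannot be read, so it stays open whether 4-methoxyphenyl also gives a lower number than cyclopropyl. Going by these compounds, it is also open whether a longer chain, an amine or a carboxylic acid on that aromatic carbon would match propyl and iodo.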